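Pyridine-nitrile series: amine substituent change on compound 1

The compounds below may be only part of what the source reports. "The series", "measured", "known", "first", "only" and "open" are said of these compounds alone.

Measured so far:
compound 1, `N#Cc1cnc(NCc2cnccc2C(F)(F)F)cc1N[C@H]1CC[C@@H](O)CC1`, 100 nM
compound 2, `N#Cc1cnc(NCc2cncnc2-c2ccccc2)cc1N[C@H]1CC[C@@H](O)CC1`, 90 nM
compound 3, `CC1(C)[C@@H](O)C[C@H]1Nc1nc(NCc2cnccc2C(F)(F)F)ncc1C#N`, 4 nM

In an assay on isolated protein for inhibition of protein kinase C theta type (Homo sapiens), read by TR-FRET, with a stated time of 2 h (a higher number here means a weaker inhibitor, a lower number a stronger inhibitor), compound 1 gives the highest of the three numbers. Compound 2 sits within the scatter of compound 1, so no order between them is claimed. Compound 3 gives a lower number, and that gap lies beyond the scatter; compound 3 differs from compound 1 both in the shared core and in the ring on the amine, so the two values alone cannot tell which part carries the gap.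

Compound 4, `CC1(C)[C@@H](Nc2cc(NCc3cnccc3C(F)(F)F)ncc2C#N)C[C@H]1C(N)=O`, is the next compound. It differs from compound 1 by 3-carbamoyl-2,2-dimethylcyclobutyl in place of 4-hydroxycyclohexyl on a nitrogen on an aromatic ring. Among the compounds with values here, the 2,2-dimethylcyclobutyl ring recalls compound 3, but the carbamoyl group in place of the hydroxyl has no measured counterpart, and no step between measured compounds covers this change.

Expectation: a step from compound 1 to compound 4 towards a lower number, a 2.5-fold lower number from compound 1 to compound 4 (0.40 log units; beyond the scatter), beyond the scatter but smaller than the gap to compound 3, given that compound 3 carries the core change too. Compound 4 is estimated at 40 nM, with a range from 10 nM to 160 nM.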

Compound 4, half-maximal inhibitory concentration: 140 nM
Estimate against measurement, compound 4: 3.5-fold (0.54 log units) below; the range from low to high includes it.
By their numbers in this assay, from the lowest: compound 3; then compounds 2, 1 and 4 (each within the scatter of the next).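

In this assay, 3-carbamoyl-2,2-dimethylcyclobutyl in place of 4-hydroxycyclohexyl on a nitrogen on an aromatic ring gives a 1.4-fold higher number from compound 1 to compound 4 (0.15 log units; within the scatter), so the two compounds are not separated. On the core of compound 1, this position therefore accepts a four-membered ring with a carbamoyl group as well as a six-membered ring with a hydroxyl group, with no readable shift in the number. Nothing measured here offers an explanation for this result.

The ring and its carbamoyl group change together in this single step, so their separate contributions stay unresolved, and opposing contributions cannot be excluded. A carboxylic acid or an amine in place of the carbamoyl group on the same 2,2-dimethylcyclobutyl ring would test how far this position depends on that group.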